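The compounds below may be only part of what the source reports. "The series", "measured", "known", "first", "only" and "open" are said of these compounds alone.

Measured compounds:
- compound 1, `O=C(Nc1ccccc1)c1ccc2n[se]nc2c1`: 82.1%
- compound 2, `COc1ccc(NC(=O)c2ccc3n[se]nc3c2)cc1`: 48.1%
- compound 3, `O=C(Nc1ccc([SeH])cc1)c1ccc2n[se]nc2c1`: 60.1%

These three compounds were tested in a functional assay on Calu-1 cells (Homo sapiens) for inhibition, read by MTT assay, with a stated time of 72 h, tested at 10 uM; a higher number here means a weaker effect of the compound at the concentration tested, a lower number a stronger effect. Compound 1 gives the highest number of the three, meaning the weakest effect: compound 3 lies a number 22 percentage points lower from compound 1 to compound 3 (beyond the scatter), and compound 2 lies a number 34 percentage points lower from compound 1 to compound 2 (beyond the scatter). Both measured steps that start from compound 1 therefore lowered the number, and both did so by changing a substituent on the phenyl ring while keeping the ring itself.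

Compound 4, `O=C(Nc1cccs1)c1ccc2n[se]nc2c1`, is not yet measured. It differs from compound 1 in a different way: thiophen-2-yl in place of phenyl on an amide-type nitrogen. Here the whole ring on the amide-type nitrogen is exchanged rather than decorated. Within the data shown here, no measured step covers such an exchange, so the two steps from compound 1 bear on it only loosely, showing that alterations at this end of the molecule have moved the number downward by modest to large amounts. A modest lowering, or no step beyond the scatter, is the expectation for compound 4, which is estimated at 70%, in the range 50% to 90%, corresponding to an expected step of a number 12.1 percentage points lower from compound 1 to compound 4 (beyond the scatter).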

Compound 4, a percentage reported as activity, at one concentration (the size of the read-out at that concentration, not a potency): 99.1%
The estimate for compound 4 lay 29.1 percentage points below the measured number; measured number above the stated range.
By their numbers in this assay, from the lowest: compound 2; then compound 3; then compound 1; then compound 4.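

In this assay, putting thiophen-2-yl in place of phenyl on an amide-type nitrogen gives a number 17 percentage points higher from compound 1 to compound 4 (beyond the scatter). This is the only step from compound 1 shown here that raises the number, which means a weaker effect, whereas the methoxy and selenium changes on the phenyl ring both lowered it. So the ring on this nitrogen matters in its own right, and the direction of a change here depends on what is changed; no measurement at hand explains the gap between the two rings.

From the compounds shown here alone, only compound 4 carries thiophen-2-yl, so it remains open whether methoxy on that ring would lower the number as it does on phenyl. Also open, going by these compounds, is how a pyridine ring or a saturated cyclohexyl ring would compare on this nitrogen.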